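Trimming an Acetyl to Methyl on the Ring

This account rests on a few compounds, and the source may have more. Where it says the series, first, only, none or still open, it means among the compounds named here.

Of the compounds shown here, two have so far been tested in an assay on HEK-293T cells for inhibition of diacylglycerol lipase-alpha (Homo sapiens), read by colorimetric assay; on this read-out higher numbers stand for weaker inhibition and lower numbers for stronger inhibition. Compound 1, `O=C(CCCCCc1ccccc1)c1nc2ccc(F)cc2o1`, gives 708 nM in this assay. Compound 2, `CC(=O)c1coc(C(=O)CCCCCCc2ccccc2)n1`, gives 123 nM in this assay, the lower of the two numbers and therefore the stronger inhibitor, with compound 1 sitting clearly above it, beyond the usual scatter of the measurement. The two differ in more than one place, so nothing can be said about which change accounts for the gap between them.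

Compound 3, `Cc1coc(C(=O)CCCCCCc2ccccc2)n1`, has not yet been measured. It differs from compound 2 in one place only: methyl in place of acetyl on an aromatic carbon. The acetyl leaves, a methyl enters, and the rest of the shared core is unchanged.

For the measured compounds named here, no pair of measured compounds shows the effect of this single change, so the expectation rests on the structural change alone. The step from compound 2 to compound 3 is expected to be a modest loss, a 2.8-fold higher number from compound 2 to compound 3 (0.45 log units; beyond the scatter), in this assay. For compound 3 the estimated result in this assay is 350 nM, within a range of 120 nM to 1200 nM.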

Compound 3, half-maximal inhibitory concentration: > 10000 nM
Compound 3: no number, only a limit (the forecaster's own chance of this, stated with the estimate: 5%); middle value at least 28-fold (1.45 log units) from the limit.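

Replacing the acetyl with a methyl on this aromatic carbon, next to the ring nitrogen, gives an at least 81-fold higher number from compound 2 to compound 3 (1.91 log units; beyond the scatter) in this assay. Compounds 1 and 2 differ in more than one place and could say nothing about any single group, whereas this pair ties a large loss of inhibition to this one position, showing that the acetyl cannot be trimmed to a methyl here without that loss. Compound 3 has only a limit of the assay and no number, so the step marks the smallest loss that fits the result, and its full size stays unknown: the limit of > 10000 nM in this assay, at which 1 of the 3 values shown sits.

The change takes away the carbonyl and the acetyl's carbon framework together, so the compounds shown cannot tell whether the carbonyl itself matters or only the size of the group at this carbon. A methyl ester, a primary amide or a carboxylic acid on the same carbon, each of which keeps a carbonyl, set against an ethyl group, which does not, would help to separate these two readings.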